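Amide-extended benzimidazole and cytotoxicity in hamster kidney cells

The source may report more compounds than this note shows. Statements on the series, on what has been measured and on what is new or still open speak of the compounds shown alone.

Measured compounds:
- compound 1 `CN1CCN(CC(=O)Nc2ccc(-c3nc4cc(Cl)c(Cl)cc4[nH]3)cc2)CC1`: 41000 nM
- compound 2 `Nc1ccc(-c2nc3cc(Cl)c(Cl)cc3[nH]2)cc1`: 30000 nM
- compound 3 `Oc1ccc(-c2nc3cc(Cl)c(Cl)cc3[nH]2)cc1`: 29000 nM

In an ADME assay on BHK cells (Mesocricetus auratus) for cytotoxicity, read by MTT assay, with a stated time of 96 h (on this read-out lower numbers stand for higher toxicity in this test and higher numbers for lower toxicity in this test), compound 2 gives 30000 nM. Among the three numbers this is the second highest; compound 3 gives 29000 nM and compound 1 gives 41000 nM, and both of these lie within the scatter of compound 2. Going by the values given here, the only step between single-point neighbours, a 1.0-fold lower number from compound 2 to compound 3 (0.01 log units; within the scatter), changes nothing beyond the scatter.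

Compound 4 `O=C(CN1CCCCC1)Nc1ccc(-c2nc3cc(Cl)c(Cl)cc3[nH]2)cc1` is not yet measured. It differs from compound 2 in one place: ((piperidin-1-yl)methyl)carbonyl in place of hydrogen on a nitrogen on an aromatic ring. Among the compounds with values here, no measured step covers this exact change. The nearest comparison is compound 1, which also carries an amide on the same nitrogen and gives 41000 nM, a number within the scatter of compound 2. On this basis compound 4 is expected to stay close to compound 2, with a step of a 1.2-fold higher number from compound 2 to compound 4 (0.08 log units; within the scatter) that would lie within the scatter. Compound 4 is therefore estimated at 36000 nM, in the range 16000 nM to 80000 nM.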

Compound 4, half-maximal cytotoxic concentration: 39000 nM
The estimate for compound 4 lay 1.1-fold (0.03 log units) below the measured number; the range from low to high includes it.
By their numbers in this assay, from the lowest: compounds 3, 2, 4 and 1 (each within the scatter of the next).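

In this assay, ((piperidin-1-yl)methyl)carbonyl in place of hydrogen on the nitrogen on an aromatic ring gives a 1.3-fold higher number from compound 2 to compound 4 (0.11 log units; within the scatter), the first step shown for a group placed on this nitrogen, and it stays within the scatter. Piperidin-1-yl in place of 4-methylpiperazin-1-yl on a saturated chain carbon bound to a carbonyl carbon gives a 1.1-fold lower number from compound 1 to compound 4 (0.02 log units; within the scatter), so the exchange of these two rings also leaves the number within the scatter. No measurement offered here accounts for either step.

Going by these compounds, it remains open whether a carboxylic acid or morpholin-4-yl in place of piperidin-1-yl would also stay within the scatter of compound 4. It is equally open whether a longer chain carrying piperidin-1-yl would do so, and the compounds shown say nothing about changes on the shared core.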